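Trimethoxyphenyl Pyrazolyl Chalcones Against a Glioblastoma Cell Line

The source may hold more compounds than are shown below. What is called first, only, known or untested is meant among the compounds shown, and "the series" means these compounds.

Compound 1 `COc1cc(-c2cc(/C=C/C(=O)c3ccc(N)cc3)[nH]n2)cc(OC)c1OC` was examined in a functional assay on SNB-19 cells (Homo sapiens) for cytotoxicity, read by sulforhodamine B assay, with a stated time of 48 h, tested at 0.1 uM (on this read-out lower numbers stand for a stronger effect and higher numbers for a weaker effect at the one concentration tested), where compound 1 gives 94%. Compound 2 `COc1ccc(-c2cc(/C=C/C(=O)c3ccc(N)cc3)[nH]n2)cc1OC` differs from compound 1 by hydrogen in place of methoxy on an aromatic carbon; in this assay compound 2 gives 90%, and the change made a number 4 percentage points lower from compound 1 to compound 2 (within the scatter). Compound 3 `COc1cc(C(=O)/C=C/c2cc(-c3cc(OC)c(OC)c(OC)c3)n[nH]2)cc(OC)c1OC` rests on a different core, and the difference between the two cores is not broken down here. In this assay compound 3 gives 90%, a read-out that cannot be told apart from that of compound 2 and that lies close to that of compound 1.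

Compound 4 `COc1ccc(-c2cc(/C=C/C(=O)c3cc(OC)c(OC)c(OC)c3)[nH]n2)cc1OC` has not yet been measured. It differs from compound 3 by hydrogen in place of methoxy on an aromatic carbon, the same change at the same place that separates compound 2 from compound 1, and among the compounds shown this change occurs two times in all. Because the earlier step of a number 4 percentage points lower from compound 1 to compound 2 (within the scatter) stayed within the scatter, the step from compound 3 to compound 4 is expected to be a number 2 percentage points lower from compound 3 to compound 4 (within the scatter). For compound 4 the read-out in this assay is estimated at 88%, with a likely range from 78% to 98%.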

Compound 4, a percentage reported as activity, at one concentration (the size of the read-out at that concentration, not a potency): 92%
Beside the measured number, compound 4's estimate is 4 percentage points below it; the range from low to high includes it.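

In this assay, putting hydrogen in place of methoxy on the core of compound 3 gives a number 2 percentage points higher from compound 3 to compound 4 (within the scatter). Set beside the earlier step on the core of compound 1, the same change gives no difference between the two cores that can be told from the scatter: the same change on two cores in this assay, a number 4 percentage points lower (within the scatter) from compound 1 to compound 2 and a number 2 percentage points higher (within the scatter) from compound 3 to compound 4, 6 percentage points apart, within the scatter of two such steps This shows that, at the one concentration tested, the change carried over from one core to the other in the sense that neither step could be told from the scatter, but it does not show that the change is without consequence in general, since it rests on only two pairs whose read-outs all lie close together and says nothing of how the pairs would compare at any other concentration.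

The compounds shown leave open how a hydroxy group or a longer chain such as ethoxy would read at this same place on the ring. They also leave open whether a carboxylic acid there would give a step that stands clear of the scatter in this assay.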